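Nitrile for Bromine on a Fused Aldehyde Core

A few compounds are considered here, and "the series" means these few. Any claim that something is new, unique, unknown or untested is made for them only; others in the source may bear on it.

Compounds measured in a functional assay on NSCLC-N6 cells (Homo sapiens) for cytotoxicity, read by MTT assay; on this read-out higher numbers stand for weaker inhibition and lower numbers for stronger inhibition:
Compound 1, `CCOC(=O)c1oc2c(Br)c(OC)cc(OC)c2c1C`, gives > 87400 nM, which is a limit of the assay and not a number.
Compound 2, `CCOC(=O)c1oc2c(C#N)c(OC)cc(OC)c2c1C`, gives "not active" (no number reported).
Compound 3, `COc1cc(OC)c2c(C)c(C=O)oc2c1Br`, gives "not active" (no number reported).

Among the three measured compounds only one entry carries a figure at all, and that figure is the limit of > 87400 nM in this assay, at which 1 of the 3 values shown sits, belonging to compound 1. Compound 3 has no single number of its own: it is reported as not active, and in this it stands together with compound 2, which is reported the same way. Nothing in these entries separates compound 3 from the other two in a way that could be read as an order.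

Compound 4, `COc1cc(OC)c2c(C)c(C=O)oc2c1C#N`, differs from compound 3 by cyano in place of bromo on an aromatic carbon, in words cyano in place of bromo on an aromatic carbon. The same pairing of a bromo and a cyano analogue appears in compound 1 and compound 2, and there both entries show no measurable inhibition. Among the measured compounds shown here, no step between measured compounds exists here, so in this assay no move beyond the usual scatter is expected in either direction for compound 4. Compound 4 is therefore estimated at 120000 nM, with a range from 40000 nM to 400000 nM, and most likely only a limit would be reported.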

Compound 4, half-maximal inhibitory concentration: "not active" (no number reported)
Compound 4 has no reported number here, and the estimate cannot be compared.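

Among the compounds shown here, compound 4 is reported as not active, as compound 3 is, so neither has a number and no step between them can be read in this assay. The only figure among the compounds shown is a limit of the assay: the limit of > 87400 nM in this assay, at which 1 of the 4 values shown sits. Going by these compounds, whether cyano in place of bromo changes inhibition at all remains open for both pairs, compound 1 with compound 2 and compound 3 with compound 4.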